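The source may hold more compounds than are shown below. What is called first, only, known or untested is meant among the compounds shown, and "the series" means these compounds.

Compound 1 `O=C1CCC[C@@H]([C@H]2C[C@@H]2c2ccccc2)O1`: > 100000 nM (a limit, not a number)
Compound 2 `O=C1C=CC[C@H](/C=C/c2ccc([N+](=O)[O-])cc2)O1`: 15400 nM

Both results come from a functional assay on A549 cells (Homo sapiens) for antiproliferative activity, read by luminescence and CellTiter-Glo, with a stated time of 48 h; a higher number here means a weaker inhibitor, a lower number a stronger inhibitor. For compound 1, the result is a limit of the assay and not a number. Within the data shown here, compound 2 gives 15400 nM, the only true number so far, so it serves as the reference point here.

Compound 3 `O=C1C=CC[C@@H](/C=C/c2ccc([N+](=O)[O-])cc2)O1` has yet to be measured. Its relation to compound 2 is simple: the two compounds have the same atoms and bonds and differ only in configuration as drawn: 1 of 2 stereo elements differ; a stereocentre at a saturated ring carbon is drawn R in compound 2 and S in compound 3. In words, a stereocentre at a saturated ring carbon is drawn R in compound 2 and S in compound 3. Among the measured compounds shown here, no measured pair shows what such a change does in this assay. The expected step is therefore none beyond the usual scatter, with no firm direction, starting from compound 2 at 15400 nM. The estimated value for compound 3 is 15000 nM, with an expected range of 5000 nM to 50000 nM.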

Compound 3, half-maximal inhibitory concentration: > 100000 nM
Compound 3 was reported as a limit (the forecaster's own chance of this, stated with the estimate: 8%); middle value at least 6.6-fold (0.82 log units) away from the limit.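

In this assay, changing nothing but the drawn configuration at a saturated ring carbon, from R to S, gives an at least 6.4-fold higher number from compound 2 to compound 3 (0.81 log units; beyond the scatter). Among these compounds, this is the first measured sign that the configuration at this stereocentre matters for activity in these cells, and the step can be tied to this one place alone because of what the pair shares: the fact that compounds 2 and 3 differ only in the configuration as drawn. As far as these compounds go, compound 3 gives > 100000 nM, which is a limit and not a number, so the true size of the step stays unknown.

The compounds shown leave open whether the R configuration would keep its advantage with an amine or a carboxylic acid in place of the nitro group. They also leave open whether the other stereo element, the same in both compounds, matters as much.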